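The compounds below may be only part of what the source reports. "The series", "measured", "known", "first", "only" and "open" are said of these compounds alone.

Compound 1 `CCN1CCN(c2cc(C)c3cc(NC(=O)c4ccc[nH]4)ccc3n2)CC1`: 14700 nM
Compound 2 `CCN1CCN(c2cc(C)c3cc(NC(=O)c4cccc(C)c4)ccc3n2)CC1`: 7800 nM
Compound 3 `CCN(CC)c1cc(C)c2cc(NC(=O)c3ccc(Cl)c(Cl)c3)ccc2n1`: a limit, > 50000 nM

In a functional assay on MCF7 cells (Homo sapiens) for antiproliferative activity, read by MTT assay, with a stated time of 72 h (a higher number here means a weaker inhibitor, a lower number a stronger inhibitor), compound 1 gives 14700 nM, and compound 2 gives 7800 nM; the two sit within the usual scatter of each other. For compound 3 the assay reports only a limit, > 50000 nM. Compound 4 `CCN1CCN(c2cc(C)c3cc(NC(=O)c4cccc(Br)c4)ccc3n2)CC1` has not yet been measured. It differs from compound 1 by 3-bromophenyl in place of 1H-pyrrol-2-yl on a carbonyl carbon. Within the data shown here, the one measured step that bears on this change is a 1.9-fold lower number from compound 1 to compound 2 (0.28 log units; within the scatter), where 3-methylphenyl replaced 1H-pyrrol-2-yl at the same place. Among the measured compounds shown here, compound 3 differs from compound 1 in more than one place, so its limit gives no guide to this step alone. The expected step is therefore a 1.6-fold lower number from compound 1 to compound 4 (0.21 log units; within the scatter). Compound 4 is estimated at 9000 nM, between 3000 nM and 30000 nM.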

Compound 4, half-maximal inhibitory concentration: 11600 nM
Compound 4: middle estimate off by 1.3-fold (0.11 log units), on the low side; the measured number falls inside the stated range.
By their numbers in this assay, from the lowest: compounds 2, 4 and 1 (each within the scatter of the next). At a limit, above all of these: compound 3.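

In this assay, a step from a ring with one hydrogen-bond donor to a ring with none gives a 1.3-fold lower number from compound 1 to compound 4 (0.10 log units; within the scatter), so this exchange on the carbonyl carbon stays within the scatter. Exchanging the ring's substituent, bromo in place of methyl on an aromatic carbon, gives a 1.5-fold higher number from compound 2 to compound 4 (0.17 log units; within the scatter). Compound 1, compound 2 and compound 4 therefore cannot be told apart in this assay. Going by these compounds, whether an amine or a carboxylic acid in place of bromo would give a step beyond the scatter remains open. Nothing measured here accounts for the size of these steps.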